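Dichloro pair on the meta-benzyl core: a forecast

A few compounds are considered here, and "the series" means these few. Any claim that something is new, unique, unknown or untested is made for them only; others in the source may bear on it.

The series is a set of benzyl-linked fused bicyclic chlorides carrying a chloromethyl group on the benzene ring. Compound 1 `ClCc1ccc(Cn2cnc3c(Cl)ncnc32)cc1` gives 2450 nM in a functional assay on EKVX cells (Homo sapiens) for cytotoxicity, read by sulforhodamine B assay, with a stated time of 48 h; on this read-out higher numbers stand for weaker inhibition of growth and lower numbers for stronger inhibition of growth. Compound 3 `ClCc1ccc(Cn2cnc3c(Cl)nc(Cl)nc32)cc1` is its congener with a second chlorine, (chloro in place of hydrogen on an aromatic carbon); in this assay compound 3 gives 17400 nM, which is a 7.1-fold higher number from compound 1 to compound 3 (0.85 log units; beyond the scatter). Compound 2 `ClCc1cccc(Cn2cnc3ncnc(Cl)c32)c1` has the same atoms as compound 1 joined differently; the difference between the two cores is not broken down here. In this assay compound 2 gives 13800 nM.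

Compound 4 `ClCc1cccc(Cn2cnc3nc(Cl)nc(Cl)c32)c1` is not yet measured in this assay. It stands to compound 2 as compound 3 stands to compound 1, the same change at the same place: chloro in place of hydrogen on an aromatic carbon. Among the compounds with values here, with only the step of a 7.1-fold higher number from compound 1 to compound 3 (0.85 log units; beyond the scatter) as precedent, the step from compound 2 to compound 4 is expected to be a 3.3-fold higher number from compound 2 to compound 4 (0.51 log units; beyond the scatter), of similar direction but allowed to be smaller, because the single earlier step of a 7.1-fold higher number from compound 1 to compound 3 (0.85 log units; beyond the scatter) was seen on a different core. For compound 4 the value expected in this assay is 45000 nM, within 13000 nM to 150000 nM.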

Compound 4, concentration for 50% growth inhibition: 930 nM
Compound 4: middle estimate off by 48-fold (1.68 log units), on the high side; measured number below the stated range.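

In this assay, chloro in place of hydrogen on an aromatic carbon, between two ring nitrogen atoms, gives a 15-fold lower number from compound 2 to compound 4 (1.17 log units; beyond the scatter), a large step in the opposite direction to a 7.1-fold higher number from compound 1 to compound 3 (0.85 log units; beyond the scatter). Within the data shown here, the effect of this change therefore does not carry over from the core of compound 1 to the core of compound 2, neither in direction nor in size: the same change on two cores in this assay, a 7.1-fold higher number (0.85 log units; beyond the scatter) from compound 1 to compound 3 and a 15-fold lower number (1.17 log units; beyond the scatter) from compound 2 to compound 4, 110-fold (2.02 log units) apart, beyond the scatter of two such steps This shows only that, across these two pairs, the outcome of the change depends on the core; with one pair per core and no compound separating the ways in which the two cores differ, it does not show which structural difference reverses the step, nor whether the reversal would hold on any further core.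

Still open, from the compounds shown here alone, is how an amine or a methoxy group at that same carbon would behave on each of the two cores. Also open, going by these compounds, is whether the reversal persists when the chloromethyl group is replaced by a hydroxymethyl group or a longer chain.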